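Working notes: nitrile to ester swap, cytotoxicity

This account rests on a few compounds, and the source may have more. Where it says the series, first, only, none or still open, it means among the compounds named here.

Measured compounds:
- compound 1 `C=C[C@@](C)(/C=C/c1ccc(O)cc1)CC/C=C/C(=O)OCC`: in a functional assay on SEM cells (Homo sapiens) for cytotoxicity, with a stated time of 72 h (on this read-out higher numbers stand for an effect only at larger amounts of compound and lower numbers for an effect already at smaller amounts), compound 1 gives > 36600 nM, which is a limit of the assay and not a number.
- compound 2 `C=C[C@@](C)(/C=C/c1ccc(O)cc1)CC/C=C/C#N`: in this assay compound 2 gives > 36600 nM, again a limit of the assay.
- compound 3 `C=C[C@@](C)(/C=C/c1ccc(O)c(/C=C/C#N)c1)CCC=C(C)C`: in this assay compound 3 gives > 36600 nM, also a limit of the assay.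

Compound 1 and compound 2 differ by ethoxycarbonyl in place of cyano on a double-bonded chain carbon bound to a double-bonded chain carbon. The step that the two limits leave unreadable from compound 2 to compound 1 cannot be read, since both ends are limits. The difference between the core of compound 2 and the core of compound 3 is not broken down here. All three values sit at the limit of > 36600 nM in this assay, at which 3 of the 3 values shown sit.

Compound 4 `C=C[C@@](C)(/C=C/c1ccc(O)c(/C=C/C(=O)OCC)c1)CCC=C(C)C` is not yet measured. It differs from compound 3 by ethoxycarbonyl in place of cyano on a double-bonded chain carbon bound to a double-bonded chain carbon, the same change as from compound 2 to compound 1, with the place described in identical words. In this assay the step that the limit leaves unreadable from compound 3 to compound 4 is expected to be small, an estimate resting on the unreadable step that the two limits leave unreadable from compound 2 to compound 1 and on compound 3 sitting at the limit of > 36600 nM in this assay, at which 3 of the 3 values shown sit. Compound 4 is therefore expected to give about 40000 nM, most likely reported as a limit again, with an estimated range from 15000 nM to 100000 nM.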

Compound 4, half-maximal effective concentration: > 36600 nM
Compound 4: only a limit was reported; the forecaster's own chance of this, stated with the estimate: 85%; the middle value does not contradict the limit.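

No step can be read between compound 3 and compound 4 in this assay, since both carry only a limit of the assay: the limit of > 36600 nM in this assay, at which 4 of the 4 values shown sit. The compounds shown leave open whether ethoxycarbonyl in place of cyano alters cytotoxicity at all, and at what concentration any of the four compounds would show an effect.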